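A few compounds are considered here, and "the series" means these few. Any claim that something is new, unique, unknown or untested is made for them only; others in the source may bear on it.

Of the compounds shown here, two have been tested so far in a functional assay on HEK293 cells (Homo sapiens) for cytotoxicity (a higher number here means that more compound is tolerated, a lower number that less compound is tolerated), on the shared core. Compound 1 `COc1ccc([C@H]2CC(=O)N(c3ccccc3C#N)C2)cc1OC1CCCC1` gives > 10000 nM as a limit of the assay, not a number. As far as these compounds go, compound 2 `COc1ccc([C@H]2CC(=O)N(c3ccc(C(F)(F)F)cc3)C2)cc1OC1CCCC1` gives > 10000 nM as a limit too, so its exact place on the scale is unknown.

Compound 3 `COc1ccc([C@H]2CC(=O)N(c3cccc([S+](C)[O-])c3)C2)cc1OC1CCCC1` changes the group on the amide-type nitrogen in a ring, and a group of 9 heavy atoms (7 carbon, 1 oxygen, 1 sulfur; one six-membered aromatic ring of carbon only) in place of a group of 10 heavy atoms (7 carbon, 3 fluorine; one six-membered aromatic ring of carbon only), on an amide-type nitrogen in a ring is the whole difference. Within the data shown here, the only measured step at that nitrogen is a step that the two limits leave unreadable from compound 1 to compound 2 and it offers no size to carry over. Compound 1 and compound 2 both end at the limit of > 10000 nM in this assay, at which 2 of the 2 values shown sit, so for compound 3 no step beyond the usual scatter is expected. In this assay the expected change is a step that the limit leaves unreadable from compound 2 to compound 3 with neither direction favoured. Compound 3 is estimated at 15000 nM with an expected range from 6000 nM to 40000 nM and will quite probably report only a limit again.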

Compound 3, half-maximal cytotoxic concentration: > 10000 nM
Compound 3 ended at the assay's limit (the forecaster's own chance of this, stated with the estimate: 85%); the middle value lies beyond the limit too.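

No step can be read between compound 1, compound 2 and compound 3 in this assay, because each ends at a limit of the assay rather than a number: the limit of > 10000 nM in this assay, at which 3 of the 3 values shown sit.

As far as these compounds go, whether the three groups on the amide-type nitrogen differ at all in this assay remains open.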